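Swapping the amine-bearing ring for pyrimidine in an amidine series

The source may report more compounds than this note shows. Statements on the series, on what has been measured and on what is new or still open speak of the compounds shown alone.

Compound 1 `Fc1ccc(C2(c3ccc(F)cc3)CNC(c3cccc(C(F)(F)F)c3)=N2)cc1`: 6.2 nM
Compound 2 `OCc1cccc(C2=NC(c3ccc(F)cc3)(c3ccc(F)cc3)CN2)c1`: 59 nM
Compound 3 `Nc1cccc(C2=NC(c3ccc(F)cc3)(c3ccc(F)cc3)CN2)c1`: 300 nM

Three compounds share one core and differ only in the group on a carbon with a double bond to nitrogen. In an assay on LM cells for displacement of a labelled ligand from Neuropeptide Y receptor type 5 (Homo sapiens) (on this read-out higher numbers stand for weaker inhibition and lower numbers for stronger inhibition), compound 3 gives the highest number of the three, with a 5.1-fold higher number from compound 2 to compound 3 (0.71 log units; beyond the scatter) and a 48-fold higher number from compound 1 to compound 3 (1.68 log units; beyond the scatter). Compound 4 `Fc1ccc(C2(c3ccc(F)cc3)CNC(c3cncnc3)=N2)cc1` differs from compound 3 in that (pyrimidin-5-yl in place of 3-aminophenyl on a carbon with a double bond to nitrogen). Within the data shown here, no measured step matches this change; the known steps (a 9.5-fold higher number from compound 1 to compound 2 (0.98 log units; beyond the scatter), a 48-fold higher number from compound 1 to compound 3 (1.68 log units; beyond the scatter)) only show that this ring tolerates change with large swings. Dropping the lone donor is expected to help somewhat, so for compound 4 the expected step is a 3.0-fold lower number from compound 3 to compound 4 (0.48 log units; beyond the scatter), and compound 4 is estimated at 100 nM (range 30 nM to 400 nM).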

Compound 4, half-maximal inhibitory concentration: 47 nM
Compound 4: the middle estimate sits 2.1-fold (0.33 log units) above what was measured, within the range that was stated.
By their numbers in this assay, from the lowest: compound 1; then compounds 4 and 2 (each within the scatter of the next); then compound 3.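

In this assay, the group on this carbon need not be a carbon-only ring: pyrimidin-5-yl replacing 3-aminophenyl gives a 6.4-fold lower number from compound 3 to compound 4 (0.81 log units; beyond the scatter), while replacing 3-(hydroxymethyl)phenyl gives a 1.3-fold lower number from compound 2 to compound 4 (0.10 log units; within the scatter). So a ring without a hydrogen-bond donor is accepted here, and with hetero atoms in the ring itself, although compound 1 gives 6.2 nM and compound 4 gives 47 nM. Nothing shown here explains these differences. Still open, from the compounds shown here alone, is how a pyridin-3-yl ring, or a pyrimidin-5-yl ring carrying an amine or a trifluoromethyl group, would fare at this position.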